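Pyrimidin-2-yl in Place of 1-Phenyl-1H-tetrazol-5-yl

This account rests on a few compounds, and the source may have more. Where it says the series, first, only, none or still open, it means among the compounds named here.

Among the compounds with values here, compound 3 `O=C(CSc1nnnn1-c1ccccc1)N/N=c1/scc(-c2ccc(Cl)cc2)n1-c1ccccc1` gives in a functional assay on C6 cells (Rattus norvegicus) for cytotoxicity, read by MTT assay, with a stated time of 24 h, tested at 25 ug/mL (a lower number here means a stronger effect, a higher number a weaker effect of the compound at the concentration tested), a value of 62.3%, the highest of the three numbers so far. Compound 2 `Cc1nnc(SCC(=O)N/N=c2/scc(-c3ccc(Cl)cc3)n2-c2ccccc2)s1` gives 53.3%, and the step of a number 9 percentage points higher from compound 2 to compound 3 (within the scatter) shows that exchanging the heteroaryl group on the sulfur left the read-out essentially unchanged. Compound 1 `O=C(CSc1nnnn1-c1ccccc1)N/N=c1/scc(-c2ccc(Br)cc2)n1-c1ccccc1` gives 47.9%, and the step of a number 14.4 percentage points higher from compound 1 to compound 3 (beyond the scatter) is the only one of the two that reaches beyond the scatter.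

Compound 4 `O=C(CSc1ncccn1)N/N=c1/scc(-c2ccc(Cl)cc2)n1-c1ccccc1` differs from compound 3 in one place: pyrimidin-2-yl in place of 1-phenyl-1H-tetrazol-5-yl on a sulfur. Within the data shown here, the step that bears on this change is the one between compound 2 and compound 3, since it also replaced the heteroaryl group on the sulfur while keeping the rest of the molecule fixed, and it stayed within the scatter. On that basis the step of a number 5.3 percentage points lower from compound 3 to compound 4 (within the scatter) is expected to be small, with no clear direction beyond the scatter. Compound 4 is therefore estimated at 57%, within a range from 45% to 70%.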

Compound 4, a percentage reported as activity, at one concentration (the size of the read-out at that concentration, not a potency): 91.1%
The estimate for compound 4 lay 34.1 percentage points below the measured number, and the stated range ends below it.
By their numbers in this assay, from the lowest: compounds 1, 2 and 3 (each within the scatter of the next, the first and the last beyond it); then compound 4.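

With pyrimidin-2-yl on the sulfur, the read-out in this assay moves clearly towards a weaker effect at the concentration tested: the change gives a number 28.8 percentage points higher from compound 3 to compound 4 (beyond the scatter), and a number 37.8 percentage points higher from compound 2 to compound 4 (beyond the scatter). The group on this sulfur therefore matters to the read-out, which the earlier exchange of 5-methyl-1,3,4-thiadiazol-2-yl for 1-phenyl-1H-tetrazol-5-yl, staying within the scatter, had not revealed. No measurement available here accounts for the shift.

The compounds shown leave open whether the weaker effect belongs to the pyrimidin-2-yl group in particular or would also appear with a pyridin-2-yl or a plain phenyl on the sulfur. They also leave open whether the same shift would hold with bromo in place of chloro on the aromatic carbon.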